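This account rests on a few compounds, and the source may have more. Where it says the series, first, only, none or still open, it means among the compounds named here.

Compound 1 `CC(=O)Nc1cccc(Nc2cc(NC3CC3)n3ncc(C#N)c3n2)c1`: 26 uL/min
Compound 2 `CC(=O)Nc1cc(Nc2cc(NC3CC3)n3ncc(C#N)c3n2)ccc1N1CCC[C@H](N)C1`: < 1 uL/min

Both compounds were run in an ADME assay on cells (Hepatocyte, Rattus norvegicus) for metabolic stability; on this read-out lower numbers stand for slow clearance and higher numbers for fast clearance. Compound 1 gives 26 uL/min. For compound 2 the assay returns only a limit, < 1 uL/min, not a number. Compound 2 thus sits at the floor of the two values shown: the limit of < 1 uL/min in this assay, at which 1 of the 2 values shown sits.

Among the compounds with values here, the one measured step, an at least 26-fold lower number from compound 1 to compound 2 (1.41 log units; beyond the scatter), accompanied 3-aminopiperidin-1-yl in place of hydrogen on an aromatic carbon. Compound 3 `CC(=O)Nc1cc(Nc2cc(NC3CC3)n3ncc(C#N)c3n2)ccc1N1CC[C@@H](N)C1` differs from compound 2 by 3-aminopyrrolidin-1-yl in place of 3-aminopiperidin-1-yl on an aromatic carbon. Within the data shown here, no measured step covers this exchange of one amine-bearing ring for another; the only step on record, an at least 26-fold lower number from compound 1 to compound 2 (1.41 log units; beyond the scatter), concerns adding such a ring, not resizing it. Since compound 2 already stands at the limit, the step to compound 3 is expected to be a number no lower from compound 2 to compound 3 (the limit leaves the size open), within the scatter. Compound 3 is therefore estimated at 1 uL/min, in the range 0.5 uL/min to 3 uL/min, most likely reported again as a limit.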

Compound 3, intrinsic clearance in a liver preparation (reported as CLH), per the amount of preparation that the assay uses in the Hepatocyte assay: 2.5 uL/min
The estimate for compound 3 lay 2.5-fold (0.40 log units) below the measured number; the measured number falls inside the stated range.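

In the Hepatocyte assay, the fall in the number is not confined to 3-aminopiperidin-1-yl: on this aromatic carbon, ortho to an acetamido group, 3-aminopyrrolidin-1-yl gives a 10-fold lower number from compound 1 to compound 3 (1.02 log units; beyond the scatter). In the Hepatocyte assay ring size also matters, with an at least 2.5-fold higher number from compound 2 to compound 3 (0.39 log units; beyond the scatter), while in a physicochemical assay for solubility, read by LC-MS, in phosphate buffer, with a stated time of 24 h, at pH 7.4 (on this read-out higher numbers stand for higher solubility and lower numbers for lower solubility), compound 2 gives 704000 nM and compound 3 gives 812000 nM, with a 1.2-fold higher number from compound 2 to compound 3 (0.06 log units; within the scatter). The clearance step between the two rings starts from a limit held by compound 2, not from a number: the limit of < 1 uL/min in the Hepatocyte assay, at which 1 of the 3 values shown sits.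

The compounds shown leave open how far the true clearance of compound 2 lies under that limit, and so the full size of the ring step. They also leave open how a morpholine ring or an open-chain amine such as dimethylamino would read at this position.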